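The source may report more compounds than this note shows. Statements on the series, on what has been measured and on what is new or still open speak of the compounds shown alone.

Compound 1 `N#Cc1ccc(NC(=O)c2cc(-c3ccccc3)ccc2O)cc1`: 1350 nM
Compound 2 `N#Cc1ccc(NC(=O)c2ccccc2O)cc1`: 4620 nM

In a functional assay on HL-60 cells (Homo sapiens) for cytotoxicity, read by luminescence and CellTiter-Glo, with a stated time of 3 days (a lower number here means a stronger inhibitor, a higher number a weaker inhibitor), compound 2 stands at 4620 nM, the higher of the two numbers. Compound 3 `Cc1ccc(O)c(C(=O)Nc2ccc(C#N)cc2)c1` differs from compound 2 by a single change: methyl in place of hydrogen on an aromatic carbon. In words, this is methyl in place of hydrogen on an aromatic carbon, para to a hydroxy group.

Among the measured compounds shown here, only one measured step bears on this change. Compound 1 carries phenyl para to a hydroxy group, and replacing it with hydrogen gave a 3.4-fold higher number from compound 1 to compound 2 (0.53 log units; beyond the scatter). For the measured compounds named here, that step is modest, and it is the only evidence for a substituent at this place. Methyl is a much smaller group than phenyl, so a smaller step toward a lower number is expected in this assay, possibly none beyond the scatter. The estimated change is a 1.5-fold lower number from compound 2 to compound 3 (0.19 log units; within the scatter). For compound 3 the estimated value is 3000 nM, with an expected range of 1500 nM to 6000 nM.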

Compound 3, half-maximal inhibitory concentration: 3920 nM
Compound 3: the middle estimate sits 1.3-fold (0.12 log units) below what was measured; the range from low to high includes it.
By their numbers in this assay, from the lowest: compound 1; then compounds 3 and 2 (each within the scatter of the next).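

In this assay, replacing hydrogen with methyl on the aromatic carbon para to a hydroxy group gives a 1.2-fold lower number from compound 2 to compound 3 (0.07 log units; within the scatter) and so does not separate the two compounds, which shows that a substituent at this place is not enough on its own to move the number beyond the scatter. Replacing phenyl with methyl at the same carbon gives a 2.9-fold higher number from compound 1 to compound 3 (0.46 log units; beyond the scatter) and is of similar size to the step from phenyl to hydrogen, so among these three groups only phenyl stands apart. Nothing available explains why phenyl and methyl differ here.

The compounds shown leave open how an ethyl chain, a methoxy group or an amine would read at this place. They also leave open whether a phenyl ring bearing a carboxylic acid would keep the standing of compound 1.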